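The compounds below may be only part of what the source reports. "The series", "measured", "known", "first", "only" and "open" are said of these compounds alone.

In a functional assay on MGC-803 cells (Homo sapiens) for inhibition, read by MTT assay, with a stated time of 48 h (on this read-out lower numbers stand for stronger inhibition and higher numbers for weaker inhibition), three compounds sharing one core have been measured. Compound 1 `COc1cc(NCc2ccccc2)cc(OC)c1OC` reads > 80000 nM, which is a limit of the assay and not a number. Compound 3 `COc1ccc(CNc2cc(OC)c(OC)c(OC)c2)cc1Cl` gives 46200 nM, while compound 2 `CCCCC(=O)N(Cc1ccc(OC)c(O)c1)c1cc(OC)c(OC)c(OC)c1` gives 66 nM, the lower of the two numbers and well beyond the scatter from compound 3. Compound 4 `COc1ccc(CN(C(=O)C=C(C)C)c2cc(OC)c(OC)c(OC)c2)cc1O` has not yet been measured. It carries 2-methylprop-1-en-1-yl in place of butyl on a carbonyl carbon. For the measured compounds named here, no measured pair shows this change, so the expectation is uncertain: a modest move toward a higher number, possibly none beyond the scatter. The expected size is a 1.5-fold higher number from compound 2 to compound 4 (0.18 log units; within the scatter). For compound 4 the estimate is 100 nM, with an expected range of 25 nM to 500 nM.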

Compound 4, half-maximal inhibitory concentration: 320 nM
Compound 4: middle estimate off by 3.2-fold (0.51 log units), on the low side; low and high end bracket the measured number.
By their numbers in this assay, from the lowest: compound 2; then compound 4; then compound 3. At a limit, above all of these: compound 1.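

In this assay, for the compounds shown here, the first direct reading at this position comes from placing 2-methylprop-1-en-1-yl in place of butyl on a carbonyl carbon, which gives a 4.8-fold higher number from compound 2 to compound 4 (0.69 log units; beyond the scatter). Both groups hold 4 carbon atoms, yet the change, which adds a double bond outside aromatic rings, still moves the number beyond the scatter. Nothing measured here explains this step.

Going by these compounds, whether the double bond or the branching carries the step remains open, and 2-methylpropyl at the same place would separate the two. On these data alone, how a longer chain there would read is also open.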